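A few compounds are considered here, and "the series" means these few. Any claim that something is new, unique, unknown or untested is made for them only; others in the source may bear on it.

Measured compounds:
compound 1, `CCCCCCSc1cc(C(F)(F)F)ccc1CNC(=O)C(C)c1ccc(NS(C)(=O)=O)c(F)c1`, 1.8 nM
compound 2, `CC(C)CCSc1cc(C(F)(F)F)ccc1CNC(=O)C(C)c1ccc(NS(C)(=O)=O)c(F)c1`, 1.4 nM
compound 3, `COc1ccc(CSc2cc(C(F)(F)F)ccc2CNC(=O)C(C)c2ccc(NS(C)(=O)=O)c(F)c2)cc1`, 2.3 nM

In an assay on CHO cells for antagonist activity at transient receptor potential cation channel subfamily V member 1 (Homo sapiens), read by FLIPR (a lower number here means a stronger inhibitor, a higher number a weaker inhibitor), compound 3 gives 2.3 nM, the highest of the three numbers, though its gaps to compound 1 and compound 2 are both within the scatter, so no order among them can be claimed. Compound 4, `CC(C(=O)NCc1ccc(C(F)(F)F)cc1Cl)c1ccc(NS(C)(=O)=O)c(F)c1`, differs from compound 3 by chloro in place of (4-methoxybenzyl)sulfanyl on an aromatic carbon. The steps seen so far, a 1.3-fold lower number from compound 1 to compound 2 (0.11 log units; within the scatter), a 1.3-fold higher number from compound 1 to compound 3 (0.11 log units; within the scatter) and a 1.6-fold higher number from compound 2 to compound 3 (0.22 log units; within the scatter), all keep a sulfanyl group in place and only change what hangs on it, and none of them moved beyond the scatter. Within the data shown here, no measured step removes that group altogether, so the present step rests on no direct precedent. The expected result for compound 4 is 8 nM, within 1.5 nM to 40 nM, which amounts to an expected step of a 3.5-fold higher number from compound 3 to compound 4 (0.54 log units; beyond the scatter).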

Compound 4, inhibition constant: 4 nM
Compound 4: middle estimate off by 2.0-fold (0.30 log units), on the high side; measured number inside the range.
By their numbers in this assay, from the lowest: compounds 2, 1, 3 and 4 (each within the scatter of the next, the first and the last beyond it).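

In this assay, a lone chloro can take the place of the whole sulfanyl side chain on this aromatic carbon and the compound remains a strong inhibitor. The cost is modest against the two alkyl chains, with a 2.9-fold higher number from compound 2 to compound 4 (0.46 log units; beyond the scatter) and a 2.2-fold higher number from compound 1 to compound 4 (0.35 log units; beyond the scatter), while a 1.7-fold higher number from compound 3 to compound 4 (0.24 log units; within the scatter) means that chloro and (4-methoxybenzyl)sulfanyl cannot be told apart. No measurement here explains these differences. Going by these compounds, whether a fluoro, methyl or amine group on this carbon would do as well remains open, as does whether this carbon needs any substituent at all.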